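This account rests on a few compounds, and the source may have more. Where it says the series, first, only, none or still open, it means among the compounds named here.

Measured compounds: compound 1 `C=CCn1c(=O)/c(=C\c2cccc(Cl)c2)[nH]c(=O)/c1=C\c1ccccc1OC` with 5200 nM; compound 2 `C=CCn1c(=O)/c(=C\c2cc(Br)ccc2F)[nH]c(=O)/c1=C\c1ccccc1OC` with 28100 nM; compound 3 `C=CCn1c(=O)/c(=C\c2ccc(F)c(Br)c2)[nH]c(=O)/c1=C\c1ccccc1OC`, reported as "not active" (no number reported) in a functional assay on MCF7 cells (Homo sapiens) for cytotoxicity, read by CCK-8 assay, with a stated time of 72 h (on this read-out higher numbers stand for weaker inhibition and lower numbers for stronger inhibition), with no number attached.

Compound 3 therefore stands outside the numbers that compound 1 and compound 2 give in this assay; it has no value of its own to place against them. Compound 4 `C=CCn1c(=O)/c(=C\c2ccc(C)cc2)[nH]c(=O)/c1=C\c1ccccc1OC` differs from compound 3 by 4-methylphenyl in place of 3-bromo-4-fluorophenyl on a double-bonded chain carbon bound to an aromatic carbon. Going by the values given here, no measured step starts or ends at compound 3, so nothing bears directly on this change. Among the compounds with values here, the only step between two measured compounds is a 5.4-fold higher number from compound 1 to compound 2 (0.73 log units; beyond the scatter), and it concerns a different pair of groups on the same position, so it shows only that the group on this carbon can shift the read-out by a modest amount. With compound 3 lacking a number, the direction of the step to compound 4 cannot be read off; the estimate rests on the span that compound 1 and compound 2 cover. Compound 4 is expected to give about 20000 nM, within 4000 nM to 100000 nM.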

Compound 4, half-maximal inhibitory concentration: "not active" (no number reported)
Compound 4 has no reported number here; no gap can be computed for the estimate.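

In this assay compound 3 and compound 4 both stand without a number, and no step can be read between them. Nothing shown here bears on this result. The compounds shown leave open how far 3-bromo-4-fluorophenyl and 4-methylphenyl differ on this read-out.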